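A few compounds are considered here, and "the series" means these few. Any claim that something is new, unique, unknown or untested is made for them only; others in the source may bear on it.

Measured so far in this series:
compound 1 `COC(CCn1cnc2c(NCc3ccc(C(=O)Nc4ccccc4N)cc3)nc(Cl)nc21)OC` — 34.2%
compound 2 `Nc1ccccc1NC(=O)/C=C/c1ccc(COCNc2nc(Nc3cccc(Cl)c3)c3ncn(C4CCCC4)c3n2)cc1` — 14.8%
compound 3 `CC(C)n1cnc2c(Nc3cccc(Cl)c3)nc(NCOCc3ccc(C(=O)Nc4ccccc4N)cc3)nc21` — 60.5%

In a functional assay on HepG2 cells (Homo sapiens) for antiproliferative activity, read by CCK-8 assay, with a stated time of 72 h, tested at 8 uM (on this read-out lower numbers stand for a weaker effect and higher numbers for a stronger effect at the one concentration tested), compound 1 gives 34.2%, the second highest of the three numbers. Compound 2 stands lower with 14.8%, beyond the scatter. Compound 3 stands higher with 60.5%, also beyond the scatter.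

Compound 4 `Nc1ccccc1NC(=O)c1ccc(CNc2nc(Cl)nc3c2ncn3C2CCCC2)cc1` has not yet been measured. Compound 4 differs from compound 1 by cyclopentyl in place of 3,3-dimethoxypropyl on an aromatic nitrogen. Within the data shown here, no measured pair isolates this change, so no step of known size exists for it; compound 2 and compound 3 carry other groups on the same kind of nitrogen but differ in several places at once, and their numbers cannot be read as a step. The change from compound 1 to compound 4 is expected to be small, at most a modest rise near the edge of the scatter, a number 5.8 percentage points higher from compound 1 to compound 4 (within the scatter). For compound 4 the expected number is 40%, in the range 22% to 60%.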

Compound 4, a percentage reported as inhibition, at one concentration (the size of the read-out at that concentration, not a potency): 74.9%
Compound 4: middle estimate off by 34.9 percentage points, on the low side; measured number above the stated range.
By their numbers in this assay, from the lowest: compound 2; then compound 1; then compound 3; then compound 4.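

In this assay the group on the aromatic nitrogen carries real weight: cyclopentyl in place of 3,3-dimethoxypropyl gives a number 40.7 percentage points higher from compound 1 to compound 4 (beyond the scatter) with the rest of the molecule unchanged. Among these compounds, this pair is the only clean reading of this position, and it shows the series is sensitive here. Nothing on hand accounts for the size of the step.

From the compounds shown here alone, whether the gain follows the ring or the loss of the oxygen atoms stays open, as this one pair changes both. An open-chain pentyl or a cyclohexyl on the same nitrogen would separate the two.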